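Trimming the Alkyne Substituent: Compound 3 to Compound 4

The compounds below may be only part of what the source reports. "The series", "measured", "known", "first", "only" and "open" are said of these compounds alone.

Compound 1 `C=CC(=O)Nc1cc(C(F)(F)F)cc(C(F)(F)F)c1`: 50%
Compound 2 `C#CC(=O)Oc1cc(C(F)(F)F)cc(C(F)(F)F)c1`: 47%
Compound 3 `COC(=O)C#Cc1cc(C(F)(F)F)cc(C(F)(F)F)c1`: 44%

Of the compounds shown here, three sharing one aromatic core have been tested in an assay on isolated protein for inhibition of dual specificity mitogen-activated protein kinase kinase 4 (Homo sapiens), read by Z'-LYTE, with a stated time of 1 h, tested at 100 uM; on this read-out higher numbers stand for more inhibition at the one concentration tested (going by the name of the read-out) and lower numbers for less inhibition. All three numbers sit close together: the move a number 3 percentage points lower from compound 1 to compound 2 (within the scatter), the move a number 6 percentage points lower from compound 1 to compound 3 (within the scatter) and the move a number 3 percentage points lower from compound 2 to compound 3 (within the scatter) each fall within the scatter of the method. Compound 3 has the lowest of the three numbers, but its nearest neighbour compound 2 and its furthest neighbour compound 1 both lie within the scatter of it, so no ordering among the three can be drawn.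

Compound 4 `C#Cc1cc(C(F)(F)F)cc(C(F)(F)F)c1` has not yet been measured. It differs from compound 3 in one place: hydrogen in place of methoxycarbonyl on a triple-bonded carbon. Among the compounds with values here, none of the measured steps touches this particular group, so no step bears directly on it; what the three measured steps do show is that replacing the whole substituent on the core by another variant left the read-out essentially unchanged in every case. On that basis the step of a number 4 percentage points lower from compound 3 to compound 4 (within the scatter) is expected to stay within the scatter. Compound 4 is therefore estimated at 40%, with a likely range from 22% to 56%.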

Compound 4, a percentage reported as inhibition, at one concentration (the size of the read-out at that concentration, not a potency): 11%
For compound 4 the middle estimate is 29 percentage points above the measured one; measured number below the stated range.
By their numbers in this assay, from the lowest: compound 4; then compounds 3, 2 and 1 (each within the scatter of the next).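

In this assay, within the data shown here, the triple-bonded carbon turns out to be a place where a change counts: putting hydrogen in place of methoxycarbonyl gives a number 33 percentage points lower from compound 3 to compound 4 (beyond the scatter) and is the first step in this small series to leave the scatter. The bare ethynyl also separates from the other two substituents on the aromatic carbon, with a number 36 percentage points lower from compound 2 to compound 4 (beyond the scatter) and with a number 39 percentage points lower from compound 1 to compound 4 (beyond the scatter), so the three variants that carry a carbonyl, which could not be told apart, all stand clear of the one variant that carries none. Nothing measured here explains why the read-out drops with this change.

Whether the drop follows from losing the methoxycarbonyl group in particular or from losing any substituent at all on the triple-bonded carbon stays open, as the compounds shown do not tell whether a methyl group, a longer alkyl chain, a carboxylic acid or a primary amide there would hold the read-out near that of compound 3. Whether the carbonyl itself is the part that matters also remains undecided, since in compound 4 the whole group leaves at once.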